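The source may report more compounds than this note shows. Statements on the series, on what has been measured and on what is new or still open speak of the compounds shown alone.

Compound 1, `Cc1nc2c(OCc3ccccc3)cccn2c1N`, gives 99% in a functional assay on the whole organism with Rattus norvegicus as the target, at a dose of 40 mg/kg by the intraperitoneal route; on this read-out lower numbers stand for less inhibition and higher numbers for more inhibition at the one dose given (going by the name of the read-out). Compound 2, `CC(C)c1nc2c(OCc3ccccc3)cccn2c1N`, gives 0%. Compound 3, `Cc1nc2c(OCc3ccc(Cl)cc3)cccn2c1N`, gives 66%.

Compound 1 stands highest of the three; compound 3 is nearest to it and compound 2 furthest. Two single-place steps lead away from compound 1: a number 99 percentage points lower from compound 1 to compound 2 (beyond the scatter), and a number 33 percentage points lower from compound 1 to compound 3 (beyond the scatter). Compound 4, `Cc1nc2c(OCc3cccs3)cccn2c1N`, carries a change in the same region as the second of these: thiophen-2-yl in place of phenyl on a saturated chain carbon bound to an oxygen on an aromatic ring. The change at the benzyl ring in compound 3 cost a large share of the inhibition, while the step to compound 2 lies elsewhere and bears less on this case. A moderate downward step is therefore expected, a number 21 percentage points lower from compound 1 to compound 4 (beyond the scatter). Compound 4 is estimated at 78%, with a range from 50% to 99%.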

Compound 4, a percentage reported as inhibition, in the whole organism at one dose (the size of the read-out at that dose, not a potency): 70%
Estimate against measurement, compound 4: 8 percentage points above, within the range that was stated.
By their numbers in this assay, from the lowest: compound 2; then compounds 3 and 4 (each within the scatter of the next); then compound 1.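

Putting thiophen-2-yl in place of phenyl on the saturated chain carbon gives, in this assay, a number 29 percentage points lower from compound 1 to compound 4 (beyond the scatter), so the change costs part of the inhibition but not all of it. Unlike the chloro step, which kept the phenyl ring, this one exchanges the ring itself, and compound 4 still gives 70% with a five-membered ring carrying sulfur. Nothing measured here explains the loss. From the compounds shown here alone, whether thiophen-3-yl, pyridin-2-yl or cyclohexyl at this place would come closer to phenyl remains open.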